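Cinnamamide series on the shared core: step to compound 4

The source may report more compounds than this note shows. Statements on the series, on what has been measured and on what is new or still open speak of the compounds shown alone.

Measured so far:
compound 1 `O=C(/C=C/c1ccc([N+](=O)[O-])cc1)Nc1cc2c(Nc3ccc(F)c(Cl)c3)ncnc2cc1O[C@H]1CCOC1` — 22800 nM
compound 2 `N#Cc1ccc(/C=C/C(=O)Nc2cc3c(Nc4ccc(F)c(Cl)c4)ncnc3cc2O[C@H]2CCOC2)cc1` — 36600 nM
compound 3 `COc1ccc(/C=C/C(=O)Nc2cc3c(Nc4ccc(F)c(Cl)c4)ncnc3cc2O[C@H]2CCOC2)cc1` — 2240 nM

In a functional assay on PC-3 cells (Homo sapiens) for cytotoxicity, read by MTT assay, with a stated time of 72 h (on this read-out lower numbers stand for stronger inhibition and higher numbers for weaker inhibition), compound 1 sits second highest of the three numbers; nearest is a 1.6-fold higher number from compound 1 to compound 2 (0.21 log units; within the scatter), furthest is a 10-fold lower number from compound 1 to compound 3 (1.01 log units; beyond the scatter). Compound 4 `O=C(/C=C/c1ccc(Br)cc1)Nc1cc2c(Nc3ccc(F)c(Cl)c3)ncnc2cc1O[C@H]1CCOC1` differs from compound 1 by bromo in place of nitro on an aromatic carbon. Within the data shown here, no measured step exchanges nitro for bromo. The two steps that touch this position, a 10-fold lower number from compound 1 to compound 3 (1.01 log units; beyond the scatter) and a 16-fold lower number from compound 2 to compound 3 (1.21 log units; beyond the scatter), show that the group placed para to a large group can move the number strongly in this assay. Bromo stands apart from all three measured groups, so the outcome is uncertain; a modest move to a lower number is expected, a 2.3-fold lower number from compound 1 to compound 4 (0.36 log units; beyond the scatter), with a wide range. Compound 4 is estimated at 10000 nM, between 2500 nM and 40000 nM.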

Compound 4, half-maximal inhibitory concentration: 28200 nM
For compound 4 the middle estimate is 2.8-fold (0.45 log units) below the measured one; low and high end bracket the measured number.
By their numbers in this assay, from the lowest: compound 3; then compounds 1, 4 and 2 (each within the scatter of the next).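

In this assay, bromo does not separate from nitro or cyano at this place: a 1.2-fold higher number from compound 1 to compound 4 (0.09 log units; within the scatter) and a 1.3-fold lower number from compound 2 to compound 4 (0.11 log units; within the scatter) both lie within the scatter. Methoxy remains the only group shown to stand apart, with a 13-fold higher number from compound 3 to compound 4 (1.10 log units; beyond the scatter) in the opposite direction, so a change from nitro to a different non-methoxy group need not move the number. No measured evidence bears on why methoxy alone stands apart here.

Open, as far as these compounds go, is whether an amine, a hydroxyl or a longer alkoxy chain at this place would track methoxy or the other three groups.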